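The compounds below may be only part of what the source reports. "The series", "measured", "known", "first", "only" and "open" are said of these compounds alone.

Measured so far in a functional assay on A549 cells (Homo sapiens) for inhibition, read by CCK-8 assay, with a stated time of 48 h; a lower number here means a stronger inhibitor, a higher number a weaker inhibitor:
- compound 1 `COc1cc(-c2ccnc3cc(-c4ccc(Cl)cc4)nn23)cc(OC)c1OC`: 3070 nM
- compound 2 `COc1cc(-c2ccnc3cc(-c4ccc5c(ccn5C)c4)nn23)cc(OC)c1OC`: 15 nM
- compound 3 `COc1cc(-c2ccnc3cc(-c4ccc5cc[nH]c5c4)nn23)cc(OC)c1OC`: 170 nM

Compound 3 holds the middle position of the three numbers. The gap to the lower end is an 11-fold higher number from compound 2 to compound 3 (1.05 log units; beyond the scatter), and the gap to the upper end appears in the step of an 18-fold lower number from compound 1 to compound 3 (1.26 log units; beyond the scatter).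

The next change leads to compound 4 `COc1cc(-c2ccnc3cc(-c4cn(C)c5ccccc45)nn23)cc(OC)c1OC`: 1-methyl-1H-indol-3-yl in place of 1H-indol-6-yl on an aromatic carbon. It falls on the same aromatic carbon that varies across the measured compounds.

For the measured compounds named here, three measured steps bear on this change, and all are large. Both indolyl groups give lower numbers than 4-chlorophenyl, as seen in a 200-fold lower number from compound 1 to compound 2 (2.31 log units; beyond the scatter) and in the step to compound 3 above. Among the indolyl compounds, the change of attachment point and methyl together gave the step of an 11-fold higher number from compound 2 to compound 3 (1.05 log units; beyond the scatter), so this position responds strongly to such changes. Going by the values given here, no measured compound is attached through the indole 3-position, and the direction therefore stays open. Compound 4 shares the 1-methyl group of compound 2 and the indolyl type of compound 3, so a value near compound 3 at 170 nM is the working expectation, with a wide margin on both sides.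

The expected result is a 1.2-fold higher number from compound 3 to compound 4 (0.07 log units; within the scatter), which amounts to no firm step beyond the scatter. For compound 4 the estimated value is 200 nM, with an expected range of 30 nM to 1500 nM.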

Compound 4, half-maximal inhibitory concentration: 1340 nM
Estimate against measurement, compound 4: 6.7-fold (0.83 log units) below, within the range that was stated.
By their numbers in this assay, from the lowest: compound 2; then compound 3; then compound 4; then compound 1.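

In this assay, the attachment point of the indole matters by itself at this aromatic carbon: with the 1-methyl group kept, 1-methyl-1H-indol-3-yl in place of 1-methyl-1H-indol-5-yl gives a large step (an 89-fold higher number from compound 2 to compound 4 (1.95 log units; beyond the scatter)), a separation of attachment point from methyl that the earlier pair of indolyl compounds did not offer. An indolyl group at this carbon therefore does not by itself secure a low number: the 1-methyl-1H-indol-3-yl group sits well above 1H-indol-6-yl (a 7.9-fold higher number from compound 3 to compound 4 (0.90 log units; beyond the scatter)) and gains only a modest step over 4-chlorophenyl (a 2.3-fold lower number from compound 1 to compound 4 (0.36 log units; beyond the scatter)). Nothing measured here gives a reason for these differences.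

Still open, going by these compounds, is how much of the gap between the two lower-number indolyl groups belongs to the methyl and how much to the attachment point, a question that 1H-indol-5-yl or 1-methyl-1H-indol-6-yl at this carbon could separate. Also open, on these data alone, is how this position responds to an amine or a carboxylic acid on the indole, and whether the order of attachment points holds with a longer chain than methyl on the indole nitrogen.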